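Swapping the aryl amide group from compound 2 to compound 3

This account rests on a few compounds, and the source may have more. Where it says the series, first, only, none or still open, it means among the compounds named here.

In a functional assay on A549 cells (Homo sapiens) for inhibition, read by CCK-8 assay, with a stated time of 72 h, tested at 1 uM (a lower number here means less inhibition of growth, a higher number more inhibition of growth at the concentration tested), compound 1 (`COc1ccc(NC(=O)C2(C(=O)Nc3ccc(Nc4ncc5cc(C(=O)N(C)C)n(C6CCCC6)c5n4)cc3)CC2)cc1`) gives 74.4% and compound 2 (`CN(C)C(=O)c1cc2cnc(Nc3ccc(NC(=O)C4(C(=O)Nc5ccc(Cl)c(C(F)(F)F)c5)CC4)cc3)nc2n1C1CCCC1`) gives 1.1%, the lower of the two numbers. Compound 3 (`CN(C)C(=O)c1cc2cnc(Nc3ccc(NC(=O)C4(C(=O)Nc5cccc(Br)c5)CC4)cc3)nc2n1C1CCCC1`) carries 3-bromophenyl in place of 4-chloro-3-(trifluoromethyl)phenyl on an amide-type nitrogen. For the measured compounds named here, one measured step bears on this place, a number 73.3 percentage points lower from compound 1 to compound 2 (beyond the scatter), which is large and beyond the scatter. Going by the values given here, with only that step as a guide, the direction is expected to be upward, and the estimated change is a number 23.9 percentage points higher from compound 2 to compound 3 (beyond the scatter). For compound 3 the expected value is 25%, with an estimated range of 3% to 60%.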

Compound 3, percent growth inhibition at one concentration: 20.2%
Estimate against measurement, compound 3: 4.8 percentage points above; the measured number falls inside the stated range.
By their numbers in this assay, from the lowest: compound 2; then compound 3; then compound 1.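

In this assay, 3-bromophenyl in place of 4-chloro-3-(trifluoromethyl)phenyl gives a number 19.1 percentage points higher from compound 2 to compound 3 (beyond the scatter), so the low number of compound 2 is not common to all halogen-bearing phenyl groups at this amide-type nitrogen. That recovery stays partial: 3-bromophenyl in place of 4-methoxyphenyl gives a number 54.2 percentage points lower from compound 1 to compound 3 (beyond the scatter), leaving 4-methoxyphenyl the highest of the three groups. No evidence on hand accounts for these differences.

Which atoms drive the gain remains open: the chlorine, the trifluoromethyl and the bromine all change in one step. Also open, going by these compounds, is how an amine or a carboxylic acid on this phenyl ring would read.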